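The compounds below may be only part of what the source reports. "The series", "measured", "known", "first", "only" and "open" are said of these compounds alone.

Working notes on the series. Compound 1 `CNc1nc(NCC(C)(C)C)cc(-c2ccccn2)n1` gives 365 nM in a functional assay on HEK293 cells for agonist activity at G-protein coupled receptor 39 (Mus musculus), read by inositol phosphate accumulation; on this read-out lower numbers stand for an effect already at smaller amounts and higher numbers for an effect only at larger amounts of compound. Compound 2 `CNc1nc(NCc2ccc(S(C)(=O)=O)cc2)cc(-c2ccccn2)n1` gives 185 nM, the lowest number of the three shown, although the number of compound 1 lies within the scatter of it. Compound 3 `COCCNc1nc(NCC2CC2)cc(-c2ccccn2)n1` gives 10000 nM, far beyond the scatter from compound 2. Compound 4 `CNc1nc(NCc2ccc(Cl)cc2)cc(-c2ccccn2)n1` has not yet been measured; it differs from compound 2 by chloro in place of methylsulfonyl on an aromatic carbon. Among the measured compounds shown here, no step between measured compounds covers this change, so the expectation for compound 4 rests on compound 2 alone. The step from compound 2 to compound 4 is expected to stay within the scatter, in either direction, about a 1.4-fold higher number from compound 2 to compound 4 (0.13 log units; within the scatter). Compound 4 is therefore estimated at 250 nM, with a range from 80 nM to 800 nM.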

Compound 4, half-maximal effective concentration: 3 nM
Estimate against measurement, compound 4: 83-fold (1.92 log units) above; the measured number lies below the stated range.
By their numbers in this assay, from the lowest: compound 4; then compounds 2 and 1 (each within the scatter of the next); then compound 3.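

In this assay, chloro in place of methylsulfonyl on this aromatic carbon gives a 62-fold lower number from compound 2 to compound 4 (1.79 log units; beyond the scatter), so the group at this place has a large effect on the number. Compounds 1 and 2 lay within the scatter of each other, yet 4-chlorophenyl in place of tert-butyl gives a 120-fold lower number from compound 1 to compound 4 (2.09 log units; beyond the scatter), so the choice of this side chain can matter greatly. Nothing at hand accounts for either change. The compounds shown leave open whether the low number is specific to chloro, or whether fluoro, bromo or methyl on the same carbon would give a similar one.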